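Allylsulfanyl in place of methylsulfanyl on an inactive core

The source may hold more compounds than are shown below. What is called first, only, known or untested is meant among the compounds shown, and "the series" means these compounds.

compound 1 `CSc1nncc2c(C)nc(C)n12` — > 48000 nM
compound 2 `CSc1nnc(C)c2c(C)nc(C)n12` — > 48000 nM

In a functional assay for inhibition, with Homo sapiens as the target (a lower number here means a stronger inhibitor, a higher number a weaker inhibitor), compound 1 gives > 48000 nM, which is a limit of the assay and not a number. Compound 2 gives > 48000 nM, also a limit. Both values sit at the limit of > 48000 nM in this assay, at which 2 of the 2 values shown sit, so the step that the two limits leave unreadable from compound 1 to compound 2 cannot be read. Compound 3 `C=CCSc1nncc2c(C)nc(C)n12` differs from compound 1 by vinyl in place of hydrogen on a saturated chain carbon bound to a sulfur. Within the data shown here, no measured step bears on this change, and compound 1 itself stands only at a limit. The step that the limit leaves unreadable from compound 1 to compound 3 is therefore expected to leave compound 3 at the limit as well. Compound 3 is estimated at 60000 nM, between 15000 nM and 300000 nM.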

Compound 3, half-maximal inhibitory concentration: 59000 nM
Compound 3: the middle estimate sits 1.0-fold (0.01 log units) above what was measured; low and high end bracket the measured number.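

No step can be read between compound 1 and compound 3, as the value of compound 1 is a limit of the assay and not a number: the limit of > 48000 nM in this assay, at which 2 of the 3 values shown sit.

The compounds shown leave open whether any group on the shared core gives a value clearly under that limit.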